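The source may report more compounds than this note shows. Statements on the series, on what has been measured and on what is new or still open speak of the compounds shown alone.

The measured compounds:
compound 1, `Cc1cc(C(=O)N2CCCCc3ccccc32)ccc1CNC(=O)Nc1ccccc1F`, giving 30 nM in a functional assay on HEK293 cells for agonist activity at Vasopressin V2 receptor (Homo sapiens), read by a luciferase reporter and cAMP accumulation; on this read-out lower numbers stand for an effect already at smaller amounts and higher numbers for an effect only at larger amounts of compound
compound 2, `Cc1cc(C(=O)N2CCCCc3ccccc32)ccc1CNC(=O)NCC(=O)OC(C)(C)C`, giving 120 nM
compound 3, `COC(=O)[C@@H]1CCCN1C(=O)NCc1ccc(C(=O)N2CCCCc3ccccc32)cc1C`, giving 100 nM

Compound 3 stands second highest of these three numbers. The step of a 3.3-fold higher number from compound 1 to compound 3 (0.52 log units; beyond the scatter) lies beyond the scatter, whereas a 1.2-fold lower number from compound 2 to compound 3 (0.08 log units; within the scatter) lies within it, so compound 2 and compound 3 cannot be told apart on this read-out. Compound 4, `Cc1cc(C(=O)N2CCCCc3ccccc32)ccc1CNC(=O)N1C[C@H](O)C[C@H]1C(=O)N(C)C`, differs from compound 3 by 2-(dimethylcarbamoyl)-4-hydroxypyrrolidin-1-yl in place of 2-(methoxycarbonyl)pyrrolidin-1-yl on a carbonyl carbon. Among the compounds with values here, no measured step alters the group on this carbonyl carbon in exactly this way. The nearest comparison is a 1.2-fold lower number from compound 2 to compound 3 (0.08 log units; within the scatter), where one non-aromatic group replaced another at the same carbonyl carbon and the number hardly moved, while a 4.0-fold higher number from compound 1 to compound 2 (0.60 log units; beyond the scatter) and a 3.3-fold higher number from compound 1 to compound 3 (0.52 log units; beyond the scatter) show that leaving the 2-fluorophenyl for either aliphatic group costs a modest amount. Since compound 4 keeps an aliphatic ring at that position, the expectation is a step of no change at the digits printed from compound 3 to compound 4 (within the scatter) that stays within the scatter. Compound 4 is estimated at 100 nM, with a range from 40 nM to 250 nM.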

Compound 4, half-maximal effective concentration: 2.3 nM
Compound 4: middle estimate off by 43-fold (1.64 log units), on the high side; measured number below the stated range.
By their numbers in this assay, from the lowest: compound 4; then compound 1; then compounds 3 and 2 (each within the scatter of the next).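

In this assay, within the data shown here, the group on this carbonyl carbon proves far more sensitive than the earlier compounds suggested: aliphatic groups there had looked interchangeable, with a 1.2-fold lower number from compound 2 to compound 3 (0.08 log units; within the scatter), yet 2-(dimethylcarbamoyl)-4-hydroxypyrrolidin-1-yl gives a 43-fold lower number from compound 3 to compound 4 (1.64 log units; beyond the scatter) and a 52-fold lower number from compound 2 to compound 4 (1.72 log units; beyond the scatter). Leaving (2-fluorophenyl)amino need not cost anything either, since a 13-fold lower number from compound 1 to compound 4 (1.12 log units; beyond the scatter); the loss seen with the two other aliphatic groups does not extend to this one. The data shown offer no measurement that bears on why this change has so large an effect.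

As far as these compounds go, the change brings in the hydroxy group and the dimethylcarbamoyl group together, so the share of each in the step stays open. Also open, from the compounds shown here alone, is how the number would respond to an amine in place of the hydroxy group, or to a carboxylic acid in place of the dimethylcarbamoyl group.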